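A larger aryl group on the triazole nitrogen of compound 3

The source may hold more compounds than are shown below. What is called first, only, known or untested is meant among the compounds shown, and "the series" means these compounds.

Compound 1, `Cc1cccc(-n2nncc2CN2C(=O)C3(C(C#N)=C(N)Oc4c3c3nc5ccccc5nc3c3ccccc43)c3ccccc32)c1`, gives in an ADME assay on HUVEC cells (Homo sapiens) for antiproliferative activity, read by MTT assay, with a stated time of 48 h (a higher number here means a weaker inhibitor, a lower number a stronger inhibitor), only a limit, > 50000 nM.
Compound 2, `CC(=O)Nc1ccc(-n2nncc2CN2C(=O)C3(C(C#N)=C(N)Oc4c3c3nc5ccccc5nc3c3ccccc43)c3ccccc32)cc1`, gives in this assay only a limit, > 50000 nM.
Compound 3, `COc1ccccc1-n1nncc1CN1C(=O)C2(C(C#N)=C(N)Oc3c(N)cc4nc5ccccc5nc4c32)c2ccccc21`, gives in this assay only a limit, > 50000 nM.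

Compound 3 therefore stands where every measured compound stands: at the limit of > 50000 nM in this assay, at which 3 of the 3 values shown sit, so no number sets it apart from the other two. For the measured compounds named here, the single step between measured compounds that differ in one place, a step that the two limits leave unreadable from compound 1 to compound 2, cannot be read because both of its ends are limits.

Compound 4, `COc1cc(-n2nncc2CN2C(=O)C3(C(C#N)=C(N)Oc4c(N)cc5nc6ccccc6nc5c43)c3ccccc32)c(OC)cc1Cl`, differs from compound 3 by 4-chloro-2,5-dimethoxyphenyl in place of 2-methoxyphenyl on an aromatic nitrogen. Going by the values given here, no measured step touches this change; the one step available gives no size in either direction. The three limits together suggest that this series, as far as it has been tested, does not reach a measurable inhibition in this assay.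

Compound 4 is therefore expected to give about 50000 nM, within a range from 20000 nM to 100000 nM, most likely again as a limit rather than a number. The expected step, a number no higher from compound 3 to compound 4 (the limit leaves the size open), is estimated to be no change beyond the scatter.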

Compound 4, half-maximal inhibitory concentration: > 50000 nM
Compound 4 gave a limit, no number (the forecaster's own chance of this, stated with the estimate: 85%); the middle value sits exactly at the limit.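

Compound 3 and compound 4 each give only a limit, so swapping 2-methoxyphenyl for 4-chloro-2,5-dimethoxyphenyl yields no readable step: the limit of > 50000 nM in this assay, at which 4 of the 4 values shown sit.

The compounds shown leave open whether any group on this aromatic nitrogen can give an actual number in this assay.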